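A few compounds are considered here, and "the series" means these few. Any claim that something is new, unique, unknown or untested is made for them only; others in the source may bear on it.

Among the compounds with values here, in an ADME assay on Caco-2 cells (Homo sapiens) for permeability, read by LC-MS, in the apical to basolateral direction, with a stated time of 60 min, at pH 6.5 (a higher number here means that the compound crosses the layer faster, a lower number that the compound crosses the layer more slowly), compound 2 (`CC(C)(C)C[C@@H](O)C(=O)N1N=CC[C@H]1C(=O)NCc1cc(Cl)ccc1-n1cnnn1`) gives 24 10^-6 cm/s and holds the highest of the three numbers so far. Compound 1 (`O=C(NCc1cc(Cl)ccc1-n1cnnn1)[C@@H]1CC=NN1C(=O)[C@H](O)c1ccccc1`) gives 7 10^-6 cm/s on the same measure, and compound 3 (`CC(C)(C)[C@@H](O)C(=O)N1C[S+]([O-])C[C@H]1C(=O)NCc1cc(Cl)ccc1-n1cnnn1`) gives 0.15 10^-6 cm/s as the lowest of the set. Compound 4 (`COC(C)(C)[C@@H](O)C(=O)N1N=CC[C@H]1C(=O)NCc1cc(Cl)ccc1-n1cnnn1`) has not yet been measured. It departs from compound 2 in one place, on a saturated chain carbon bound to a carbonyl carbon and an oxygen on a saturated carbon (1-methoxy-1-methylethyl in place of neopentyl on a saturated chain carbon bound to a carbonyl carbon and an oxygen on a saturated carbon), where 1-methoxy-1-methylethyl stands in place of neopentyl.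

Within the data shown here, only one measured step falls at that place. It is a 3.4-fold higher number from compound 1 to compound 2 (0.54 log units; beyond the scatter) with neopentyl in place of phenyl, a modest move beyond the scatter. Compound 3 differs from compound 2 in more than one place, so the wide gap between their values gives no guide to this exchange. With the size of that single step as the guide, and with a hydrogen-bond acceptor counted in the entering group, a modest fall is expected, though the data cannot settle this. The expected step is a 2.2-fold lower number from compound 2 to compound 4 (0.34 log units; beyond the scatter) and so points downward. For compound 4 the estimate is 11 10^-6 cm/s with a range of 4 10^-6 cm/s to 24 10^-6 cm/s as the expected bounds.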

Compound 4, apparent permeability: 1.7 10^-6 cm/s
For compound 4 the middle estimate is 6.5-fold (0.81 log units) above the measured one, and the stated range ends above it.
By their numbers in this assay, from the lowest: compound 3; then compound 4; then compound 1; then compound 2.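

Within the data shown here, at the saturated chain carbon bound to a carbonyl carbon and an oxygen on a saturated carbon, this assay records a 14-fold lower number from compound 2 to compound 4 (1.15 log units; beyond the scatter) when 1-methoxy-1-methylethyl replaces neopentyl, a larger move than a 3.4-fold higher number from compound 1 to compound 2 (0.54 log units; beyond the scatter) for the only exchange previously seen at this place. The entering group differs from neopentyl in carrying an oxygen and a hydrogen-bond acceptor, with no ring and no net charge on either side, so this position responds strongly to an exchange between two open-chain groups of equal heavy-atom count. The comparison with phenyl gives a 4.1-fold lower number from compound 1 to compound 4 (0.61 log units; beyond the scatter) for 1-methoxy-1-methylethyl in place of phenyl, which puts phenyl between the two open-chain groups, and nothing available gives a reason for this order.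

Still open, going by these compounds, is whether the fall follows the oxygen itself or the methyl group capping it. A hydroxyl in place of the methoxy, a tert-butyl group, or an amine at this place on the core of compound 2 would bear on that question, as would a longer ether chain.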